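The compounds below may be only part of what the source reports. "The series", "measured", "known", "first", "only" and "open" are said of these compounds alone.

Of the compounds shown here, two have been measured so far in a functional assay for inhibition, with Homo sapiens as the target; on this read-out lower numbers stand for stronger inhibition and higher numbers for weaker inhibition. Compound 1, with the structure `C=CCn1ncc2c(Br)nc(Cc3ccccc3)n2c1=O`, gives in this assay only the limit of > 48000 nM, which is a boundary of the measurement and not a number. Compound 2, with the structure `COc1ccc(-c2ncc3cnnc(O)n23)cc1`, likewise gives in this assay only the limit of > 48000 nM. Among the measured compounds shown here, compound 2 therefore stands at the limit of > 48000 nM in this assay, at which 2 of the 2 values shown sit, so its place among the numbers is known only as a limit, and no step between the two measured compounds can be counted.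

The next compound, compound 3, has the structure `Oc1nncc2cnc(-c3ccccc3)n12`. It differs from compound 2 by hydrogen in place of methoxy on an aromatic carbon. For the measured compounds named here, since compound 2 shows only a limit, no measured step can guide the expectation; a change of this kind is expected to give no shift beyond the usual scatter in this assay, and the likely outcome is again a limit rather than a number. The step is expected to be a step that the limit leaves unreadable from compound 2 to compound 3. Compound 3 is thus expected to give about 60000 nM in this assay, somewhere between 20000 nM and 200000 nM.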

Compound 3, half-maximal inhibitory concentration: > 48000 nM
Compound 3: a limit, no number; the forecaster's own chance of this, stated with the estimate: 85%; the middle value is on the limit's open side.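

No step can be read between compound 2 and compound 3, since each gives only a limit in this assay and not a number: the limit of > 48000 nM in this assay, at which 3 of the 3 values shown sit.

The compounds shown leave open how strongly any of them inhibits, and what hydrogen in place of methoxy on the aromatic carbon does to that inhibition.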